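This account rests on a few compounds, and the source may have more. Where it says the series, first, only, none or still open, it means among the compounds named here.

Working notes on the series.

Compound 1 `COc1ccc(C(=O)/C=C/c2cc(Br)c(Br)n2C)c(OC)c1` and compound 2 `COc1ccc(C(=O)/C=C/c2cc(Br)c(Br)[nH]2)c(OC)c1` share one core; compound 3 `O=c1cc(-c2cc(Br)c(Br)[nH]2)oc2ccccc12` is built on a different core, and the difference between the two cores is not broken down here. All three were run in a functional assay on WRL68 cells (Homo sapiens) for cytotoxicity, read by MTT assay, with stated times of 6 h and 48 h; on this read-out higher numbers stand for weaker inhibition and lower numbers for stronger inhibition. In this assay compound 2 gives 9220 nM, and compound 1 gives 640 nM. The change between them, (methyl in place of hydrogen on an aromatic nitrogen), made a step of a 14-fold lower number from compound 2 to compound 1 (1.16 log units; beyond the scatter). In this assay compound 3 gives only a limit, >= 100000 nM; this is the limit of >= 100000 nM in this assay, at which 1 of the 3 values shown sits, not a number.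

Compound 4 `Cn1c(-c2cc(=O)c3ccccc3o2)cc(Br)c1Br` is not yet measured. It differs from compound 3 by methyl in place of hydrogen on an aromatic nitrogen, and the place lines of this change and of the change from compound 2 to compound 1 read the same word for word, so it is the same change carried onto the core of compound 3. Whether the step repeats there cannot be read off from one pair, and the starting point of compound 3 is a limit rather than a number, so any expectation for compound 4 is loose. Among the measured compounds shown here, still, the step from compound 2 to compound 1 in this assay is the only guide, and on it a step of about an at least 6.6-fold lower number from compound 3 to compound 4 (0.82 log units; beyond the scatter) is expected for compound 4, with a real chance that the read-out again stops at a limit. The estimate for compound 4 in this assay is 15000 nM, expected to fall between 3000 nM and 100000 nM.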

Compound 4, half-maximal inhibitory concentration: >= 100000 nM
Compound 4 gave a limit, no number; the forecaster's own chance of this, stated with the estimate: 40%; middle value at least 6.6-fold (0.82 log units) from the limit.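

In this assay compound 4 gives >= 100000 nM as a limit and not a number. With compound 3 also at a limit, no step can be read between compound 3 and compound 4: the limit of >= 100000 nM in this assay, at which 2 of the 4 values shown sit.

As far as these compounds go, whether methyl in place of hydrogen on an aromatic nitrogen lowers the number on the core of compound 3, as it does on the core of compound 1, stays open.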